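A few compounds are considered here, and "the series" means these few. Any claim that something is new, unique, unknown or untested is made for them only; others in the source may bear on it.

Working notes on the series, read in a functional assay on HL-60 cells (Homo sapiens) for inhibition, read by MTT assay, with a stated time of 72 h; on this read-out higher numbers stand for weaker inhibition and lower numbers for stronger inhibition:

- compound 1 `CC(=O)c1ccc(N2CCN(C(=O)c3oc(C)nc3-c3ccccc3)CC2)cc1`: "not active" (no number reported)
- compound 2 `Cc1nc(-c2ccccc2)c(C(=O)N2CCN(c3cccc(C(F)(F)F)c3)CC2)o1`: 153 nM

In this assay, within the data shown here, compound 2 gives 153 nM, the only number available so far, so it can be ranked only against compound 1, which gives "not active" (no number reported) and no number. The next compound is compound 3 `Cc1nc(-c2ccccc2)c(C(=O)N2CCN(c3ccccc3)CC2)o1`, not yet measured. Going to it from compound 2 is the change hydrogen in place of trifluoromethyl on an aromatic carbon, or 3-(trifluoromethyl)phenyl to phenyl. Among the measured compounds shown here, no measured pair shows this change, so its size cannot be calibrated. For the measured compounds named here, the two results show only that activity differs between compound 2 and compound 1. A moderate move towards weaker inhibition is expected in this assay, with wide uncertainty, and a result without a number remains possible. The estimated step is a 3.3-fold higher number from compound 2 to compound 3 (0.51 log units; beyond the scatter). For compound 3 the expected value is 500 nM, with an estimated range of 100 nM to 3000 nM.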

Compound 3, half-maximal inhibitory concentration: 39.1 nM
The estimate for compound 3 lay 13-fold (1.11 log units) above the measured number; the whole stated range lies above it.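

In this assay, among these compounds, hydrogen in place of trifluoromethyl on an aromatic carbon gives a 3.9-fold lower number from compound 2 to compound 3 (0.59 log units; beyond the scatter) and is the first measured step. At this place, meta to a large group, trifluoromethyl is therefore not required for activity, and in this pair the compound with plain phenyl is the stronger inhibitor. Nothing at hand bears on the reason for this difference.

On these data alone, it remains open whether a fluorine atom, a methoxy group or an amine on the same aromatic carbon would give a number close to that of compound 3 or to that of compound 2, so a single pair does not show whether any group at this place weakens inhibition or only trifluoromethyl does. Also open, as far as these compounds go, is whether the same change at another carbon of this ring, or on a different core, would give a step of similar direction and size.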